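Trifluoromethoxyphenyl sulfonyl amides: positional pair on two cores

The source may hold more compounds than are shown below. What is called first, only, known or untested is meant among the compounds shown, and "the series" means these compounds.

Measured compounds:
compound 1 `CC(O)(CS(=O)(=O)c1cccc(OC(F)(F)F)c1)C(=O)Nc1ccc(S(F)(F)(F)(F)F)cc1`: 23700 nM
compound 2 `CC(O)(CS(=O)(=O)c1ccccc1OC(F)(F)F)C(=O)Nc1ccc(S(F)(F)(F)(F)F)cc1`: 19900 nM
compound 3 `CC(O)(CS(=O)(=O)c1cccc(OC(F)(F)F)c1)C(=O)Nc1cccc(S(F)(F)(F)(F)F)c1`: 20200 nM

All three numbers come from a functional assay on VCaP cells (Homo sapiens) for antiproliferative activity, read by propidium iodide staining, with a stated time of 96 h; a lower number here means a stronger inhibitor, a higher number a weaker inhibitor. Compound 1 gives 23700 nM and compound 2 gives 19900 nM in this assay; the step between them is a 1.2-fold lower number from compound 1 to compound 2 (0.08 log units; within the scatter), so the two cannot be told apart. The change that separates them is 2-(trifluoromethoxy)phenyl in place of 3-(trifluoromethoxy)phenyl on a sulfonyl sulfur. Going by the values given here, compound 3 gives 20200 nM in this assay, close to both of the others; no step is given for compound 3 against compound 1, and the difference between the two cores is not broken down here. All three values sit in the same narrow band.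

Compound 4 `CC(O)(CS(=O)(=O)c1ccccc1OC(F)(F)F)C(=O)Nc1cccc(S(F)(F)(F)(F)F)c1` has not been measured in this assay. It differs from compound 3 by 2-(trifluoromethoxy)phenyl in place of 3-(trifluoromethoxy)phenyl on a sulfonyl sulfur. Among the compounds with values here, this is the same change that separates compound 1 from compound 2, made in the same place, so the only guide is that earlier pair. Because a 1.2-fold lower number from compound 1 to compound 2 (0.08 log units; within the scatter) lies within the scatter, the expected step from compound 3 to compound 4 is likewise small, estimated as a 1.2-fold lower number from compound 3 to compound 4 (0.07 log units; within the scatter). On that basis compound 4 is expected to give about 17000 nM in this assay, with a plausible range from 9000 nM to 35000 nM. The estimate rests on a single measured pair and on the close values of compound 1, compound 2 and compound 3; it assumes nothing about the two cores beyond their similar numbers.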

Compound 4, half-maximal inhibitory concentration: 13900 nM
Estimate against measurement, compound 4: 1.2-fold (0.09 log units) above; the measured number falls inside the stated range.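

In this assay, 2-(trifluoromethoxy)phenyl in place of 3-(trifluoromethoxy)phenyl on a sulfonyl sulfur gives a 1.5-fold lower number from compound 3 to compound 4 (0.16 log units; within the scatter), a step that, like the earlier one, cannot be read as a real difference in activity. Set side by side, the two steps cannot be told apart: the same change on two cores in this assay, a 1.2-fold lower number (0.08 log units; within the scatter) from compound 1 to compound 2 and a 1.5-fold lower number (0.16 log units; within the scatter) from compound 3 to compound 4, 1.2-fold (0.09 log units) apart, within the scatter of two such steps. Going by these compounds alone, this shows only that moving the trifluoromethoxy group leaves the number within the scatter on both cores; it does not show that the move improves activity, and with just two pairs, neither with a readable step, it says nothing about whether a real effect would carry from one core to another or how the change would behave on any further core.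

The compounds shown leave open whether a nitrile, an amine or a carboxylic acid in place of the trifluoromethoxy group would produce a step beyond the scatter in this assay. Also open, going by these compounds, is whether the same holds for a longer chain in place of the methyl group on the shared core, and whether any such change would behave alike on both cores.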